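The source may hold more compounds than are shown below. What is called first, only, known or untested is meant among the compounds shown, and "the series" means these compounds.

Working notes on the series. Compound 1 `c1ccc(-c2ccno2)c(OCC2=NCCN2)c1` carries one core with a non-aromatic five-membered ring on a saturated chain carbon bound to an oxygen on an aromatic ring; in a functional assay for activation of Alpha-1D adrenergic receptor (Homo sapiens) (a higher number here means that more compound is needed for the effect, a lower number that less compound is needed), compound 1 gives 100 nM. Compound 2 `c1ccc(-c2ccno2)c(OCc2c[nH]cn2)c1` differs from it by a group of 5 heavy atoms (3 carbon, 2 nitrogen; one five-membered aromatic ring with 2 hetero atoms) in place of a group of 5 heavy atoms (3 carbon, 2 nitrogen; one five-membered non-aromatic ring with 2 hetero atoms), on a saturated chain carbon bound to an oxygen on an aromatic ring. In this assay compound 2 gives only a limit, < 100000 nM. Accordingly a step that the limit leaves unreadable from compound 1 to compound 2. Compound 3 `c1ccc(-c2cnco2)c(NCC2=NCCN2)c1` stands on another core; the difference between the two cores is not broken down here. In this assay compound 3 gives only a limit, < 5020 nM. Compound 4 `c1ccc(-c2cnco2)c(NCc2c[nH]cn2)c1` differs from compound 3 by a group of 5 heavy atoms (3 carbon, 2 nitrogen; one five-membered aromatic ring with 2 hetero atoms) in place of a group of 5 heavy atoms (3 carbon, 2 nitrogen; one five-membered non-aromatic ring with 2 hetero atoms), on a saturated chain carbon bound to a nitrogen on an aromatic ring; this is the same kind of change as before but not the same, the place being a saturated chain carbon bound to a nitrogen on an aromatic ring rather than to an oxygen. In this assay the expected step is an at least 2.9-fold higher number from compound 3 to compound 4 (0.47 log units; beyond the scatter), beside the earlier unreadable one, and rests on compound 3 sitting at the limit of < 5020 nM in this assay, at which 1 of the 3 values shown sits. Compound 4 is estimated at 15000 nM, between 2000 nM and 100000 nM.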

Compound 4, half-maximal effective concentration: < 252 nM
Compound 4 was reported as a limit; the forecaster's own chance of this, stated with the estimate: 60%; middle value at least 59-fold (1.77 log units) from the limit.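

Compound 3 and compound 4 are both reported only as limits, so the step between them cannot be read. The compounds shown leave open the size and direction of the change to 1H-imidazol-4-yl on either core.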